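Halogen on the phenyl ring and loss of antiproliferative read-out

A few compounds are considered here, and "the series" means these few. Any claim that something is new, unique, unknown or untested is made for them only; others in the source may bear on it.

Measured compounds:
compound 1 `OC(CCn1nc2c(Br)c(Br)c(Br)c(Br)c2n1)c1ccc(Br)cc1`: 0%
compound 2 `OC(CCn1nc2c(Br)c(Br)c(Br)c(Br)c2n1)c1ccccc1`: 13%
compound 3 `OC(CCn1nc2c(Br)c(Br)c(Br)c(Br)c2n1)c1cccc(Cl)c1`: 0%

In a functional assay on MCF7 cells (Homo sapiens) for antiproliferative activity, read by MTT assay, with a stated time of 24 h, tested at 100 uM (a higher number here means a weaker effect of the compound at the concentration tested, a lower number a stronger effect), compound 2 gives 13%, the highest of the three numbers. Its nearest neighbour is compound 1, which in this assay gives 0%, and compound 3, in this assay at 0%, lies equally far away; both of these steps stand beyond the scatter. Compound 4 `OC(CCn1nc2c(Br)c(Br)c(Br)c(Br)c2n1)c1cccc(Br)c1` is not yet measured. It differs from compound 2 by bromo in place of hydrogen on an aromatic carbon, on an aromatic carbon of the six-membered aromatic ring of carbon only.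

For the measured compounds named here, two measured steps bear on this change. Going from compound 1 to compound 2 removes a bromo from that ring and the read-out rises: a number 13 percentage points higher from compound 1 to compound 2 (beyond the scatter). Going from compound 2 to compound 3 adds a chloro to that ring and the read-out falls: a number 13 percentage points lower from compound 2 to compound 3 (beyond the scatter). Both halogen-bearing phenyl rings, compound 1 and compound 3, sit at the bottom of the range, so a bromo entering compound 2 is expected to bring the read-out down by a modest step of similar size.

Compound 4 is therefore estimated at 0%, within 0% to 12%, which is expected to mean a number 13 percentage points lower from compound 2 to compound 4 (beyond the scatter).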

Compound 4, a percentage reported as activity, at one concentration (the size of the read-out at that concentration, not a potency): 1%
For compound 4 the middle estimate is 1 percentage points below the measured one; the measured number falls inside the stated range.
By their numbers in this assay, from the lowest: compounds 1, 3 and 4 (each within the scatter of the next); then compound 2.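

In this assay, the change from phenyl to 3-bromophenyl comes with a number 12 percentage points lower from compound 2 to compound 4 (beyond the scatter), so a bromo meta to a large group belongs with the 3-chlorophenyl of compound 3 and the 4-bromophenyl of compound 1 at the low end of the range, and compound 2, with no halogen on this ring, stands apart from all three. Among the halogen-bearing compounds the result adds no separation: bromo in place of chloro at this place gives a number 1 percentage points higher from compound 3 to compound 4 (within the scatter), and 3-bromophenyl in place of 4-bromophenyl gives a number 1 percentage points higher from compound 1 to compound 4 (within the scatter), so in this small set the presence of a halogen on the ring, and neither its kind nor the two placements compared, goes with the difference in read-out. Nothing measured here offers an explanation for this behaviour of the halogen-bearing rings.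

As far as these compounds go, whether the lower read-out belongs to halogens alone stays open, as a methoxy, an amine or a carboxylic acid at the same place could fall on either side. From the compounds shown here alone, it is also open whether the same pattern would hold with a longer chain between the shared core and the carbon bearing the hydroxyl group.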